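Changing the aromatic ring on the chain of compound 2

The source may hold more compounds than are shown below. What is called first, only, known or untested is meant among the compounds shown, and "the series" means these compounds.

Measured so far:
compound 1, `N#C/C(=C\c1c(F)c(F)c(F)c(F)c1F)C(=O)c1c[nH]c2ccccc12`: 18000 nM
compound 2, `N#C/C(=C\c1ccc[nH]1)C(=O)NCc1ccc(Cl)c(Cl)c1`: > 50000 nM

Both numbers come from a functional assay on SW480 cells (Homo sapiens) for inhibition, read by MTT assay, with a stated time of 72 h; a lower number here means a stronger inhibitor of growth, a higher number a weaker inhibitor of growth. Compound 1 gives an actual number in this assay. For compound 2 the figure is only a limit of the assay, not a measured number, as shown by the limit of > 50000 nM in this assay, at which 1 of the 2 values shown sits. Compound 3, `COc1ccc(/C=C(\C#N)C(=O)NCc2ccc(Cl)c(Cl)c2)cc1`, is the unmeasured compound. It differs from compound 2 in one place: 4-methoxyphenyl in place of 1H-pyrrol-2-yl on a double-bonded chain carbon bound to a double-bonded chain carbon, a six-membered aromatic ring of carbon only taking the place of a five-membered aromatic ring with one hetero atom. Among the compounds with values here, no measured pair shows the effect of this kind of change, so there is nothing to set its size from. The step expected is an at least 1.1-fold lower number from compound 2 to compound 3 (0.04 log units; that floor lies within the scatter), which is no change beyond the usual scatter. Compound 3 is estimated at 45000 nM, with a range from 15000 nM to 150000 nM, and a fair chance that the assay again reports only a limit.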

Compound 3, concentration for 50% growth inhibition: 95000 nM
Compound 3: middle estimate off by 2.1-fold (0.32 log units), on the low side; low and high end bracket the measured number.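

No size can be read for the step from compound 2 to compound 3, because the value of compound 2 is only a limit of the assay: the limit of > 50000 nM in this assay, at which 1 of the 3 values shown sits.

The compounds shown leave open whether 4-methoxyphenyl in place of 1H-pyrrol-2-yl strengthens growth inhibition, weakens it or leaves it unchanged.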